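Deoxyuridine analogues: cytotoxicity at a single concentration

The source may hold more compounds than are shown below. What is called first, only, known or untested is meant among the compounds shown, and "the series" means these compounds.

Measured compounds:
Compound 1 `CC(C)(C)c1ccc(Cn2cc(-c3cn([C@H]4C[C@H](O)[C@@H](CO)O4)c(=O)[nH]c3=O)nn2)cc1` gives 106% in a functional assay on MDA-MB-231 cells (Homo sapiens) for cytotoxicity, read by sulforhodamine B assay, tested at 10 uM; on this read-out higher numbers stand for more inhibition at the one concentration tested (going by the name of the read-out) and lower numbers for less inhibition.
Compound 2 `CC(=O)OC[C@H]1O[C@@H](n2cc(-c3cn(Cc4ccc(C(C)(C)C)cc4)nn3)c(=O)[nH]c2=O)C[C@@H]1OC(C)=O` gives 105% in this assay.
Compound 3 `CC(=O)OC[C@H]1O[C@@H](n2cc(-c3cc(C)no3)c(=O)[nH]c2=O)C[C@@H]1OC(C)=O` gives 106% in this assay.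

All three measured compounds sit at the top of the read-out in this assay. Compound 3 is level with compound 1 at the digits shown, and together they are the highest of the three numbers; compound 2 sits only a single digit below, which is within the scatter, so no order among the three can be claimed. Compound 1 and compound 2 share the triazole-bearing core and differ in the acetyl groups on the sugar; compound 3 carries the smaller five-membered ring with 1 nitrogen and 1 oxygen on the same acetylated sugar.

Compound 4 `CC(=O)OC[C@H]1O[C@@H](n2cc(-c3cc(-c4ccc(C(C)C)cc4)no3)c(=O)[nH]c2=O)C[C@@H]1OC(C)=O` is not yet measured. It differs from compound 3 as follows: 4-isopropylphenyl in place of methyl on an aromatic carbon. Among the measured compounds shown here, no step between two measured compounds matches this change, so the size of its effect is not known from the data. Given that compound 3 already gives 106%, and that all three measured compounds are level with one another within the scatter whatever group sits on the five-membered ring, the expected step of a number 6 percentage points lower from compound 3 to compound 4 (within the scatter) is none beyond the scatter. Compound 4 is therefore estimated at 100%, with a range of 85% to 110%.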

Compound 4, a percentage reported as inhibition, at one concentration (the size of the read-out at that concentration, not a potency): 83.2%
For compound 4 the middle estimate is 16.8 percentage points above the measured one; the whole stated range lies above it.
By their numbers in this assay, from the lowest: compound 4; then compounds 2, 1 and 3 (each within the scatter of the next).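

In this assay, among the compounds shown here, the place on the five-membered aromatic ring with 1 nitrogen and 1 oxygen, next to the ring nitrogen, proves sensitive to the group it carries: 4-isopropylphenyl in place of methyl gives a number 22.8 percentage points lower from compound 3 to compound 4 (beyond the scatter), the only step in this small set that lies beyond the scatter. The earlier compounds shown here offered no step at this place and stood level within the scatter, so they gave no sign that the substituent on this ring could move the read-out; even so, compound 4 keeps a substantial 83.2% at the one concentration tested. No measurement at hand bears on the reason for this step.

With only methyl and 4-isopropylphenyl shown at this place, it remains open whether the drop goes with the phenyl ring itself or with the isopropyl group on it, and an unsubstituted phenyl ring or a phenyl ring bearing an amine or a carboxylic acid would separate these readings. Also open, as far as these compounds go, is whether the same change would give a step of similar size on the sugar with free hydroxyl groups, as carried by compound 1, in place of the acetylated sugar.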